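Compound 3: the 3-(sulfamoylamino)pyrrolidin-1-yl group leaves

The source may report more compounds than this note shows. Statements on the series, on what has been measured and on what is new or still open speak of the compounds shown alone.

Measured in an ADME assay on microsomes from liver (Homo sapiens) for metabolic stability, read by LC-MS, with NADPH named in the record, with a stated time of 60 min, tested at 1 uM, in the absence of a further agent; a lower number here means that less of the compound is left, a higher number that more of the compound is left (both values are limits):
- compound 1 `COc1ccc(-c2c(C)nc3c(N4CC[C@@H](NS(C)(=O)=O)C4)cc(C)nn23)cc1OC` gives > 95% as a limit
- compound 2 `COc1ccc(-c2c(C)nc3c(N4CC[C@@H](NS(N)(=O)=O)C4)cc(C)nn23)cc1OC` gives > 95% as a limit

Compound 2 has no exact number in this assay and stands only at a limit. Going by the values given here, the sole evidence is the limit of > 95% in this assay, at which 2 of the 2 values shown sit, and nothing more. Among the compounds with values here, the one measured step, a step that the two limits leave unreadable from compound 1 to compound 2, offers no size to carry forward.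

Compound 3 `COc1ccc(-c2c(C)nc3c(N4CC=CC4)cc(C)nn23)cc1OC` differs from compound 2 in one place: a group of 5 heavy atoms (4 carbon, 1 nitrogen; one five-membered non-aromatic ring with 1 hetero atom) in place of a group of 10 heavy atoms (4 carbon, 3 nitrogen, 2 oxygen, 1 sulfur; one five-membered non-aromatic ring with 1 hetero atom), on an aromatic carbon. Within the data shown here, the 3-(sulfamoylamino)pyrrolidin-1-yl group leaves, and no measured step covers a change of this kind. The expectation therefore rests on weak ground: some fall in this assay is expected, of uncertain size, since only the limit of compound 2 can serve as a starting point. The expected change is a number at least 35 percentage points lower from compound 2 to compound 3 (beyond the scatter) as estimated here. For compound 3 the estimate is 60%, with an expected range from 25% to 92% in this assay.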

Compound 3, percent of the compound remaining: > 95%
Compound 3 was reported as a limit; the forecaster's own chance of this, stated with the estimate: 15%; middle value at least 35 percentage points away from the limit.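

No step among compound 1, compound 2 and compound 3 can be read in this assay, since all three stand at one limit: the limit of > 95% in this assay, at which 3 of the 3 values shown sit.

Going by these compounds, how much of each compound actually remains, and whether replacing the 3-(sulfamoylamino)pyrrolidin-1-yl group changes that amount, stays open.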